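A few compounds are considered here, and "the series" means these few. Any claim that something is new, unique, unknown or untested is made for them only; others in the source may bear on it.

Of the compounds shown here, three built on one shared core have been tested in a functional assay on MDA-MB-231 cells (Homo sapiens) for antiproliferative activity, read by MTT assay, with a stated time of 72 h; a higher number here means a weaker inhibitor, a lower number a stronger inhibitor. Compound 1 `O=C(Nc1ccc(S(=O)(=O)Nc2cccc(-c3nc(-c4ccc(NC(=O)c5cccnc5)cc4Cl)no3)c2)cc1)NC1CCCC1` gives only a limit of the assay, > 10000 nM. Compound 2 `COc1ccc(NC(=O)Nc2cccc(-c3nc(-c4ccc(NC(=O)c5cccnc5)cc4Cl)no3)c2)cc1C(F)(F)F` gives 1700 nM, the highest of the two numbers recorded, while compound 3 `CS(=O)(=O)Nc1ccc(NC(=O)Nc2cccc(-c3nc(-c4ccc(NC(=O)c5cccnc5)cc4Cl)no3)c2)cc1C(F)(F)F` gives 700 nM. Going by the values given here, the single measured step, a 2.4-fold lower number from compound 2 to compound 3 (0.39 log units; beyond the scatter), is modest though beyond the scatter. Compound 4 `CC(=O)Nc1ccc(NC(=O)Nc2cccc(-c3nc(-c4ccc(NC(=O)c5cccnc5)cc4Cl)no3)c2)cc1` has not yet been measured; it differs from compound 2 by 4-acetamidophenyl in place of 4-methoxy-3-(trifluoromethyl)phenyl on an amide-type nitrogen. Among the compounds with values here, that measured step bears on this change, since it too replaces the methoxy, with methanesulfonamido, but the loss of the trifluoromethyl has no measured counterpart. A small drop in number, or none beyond the scatter, is therefore expected. Compound 4 is expected to give 1200 nM, between 400 nM and 4000 nM. The expected step is a 1.4-fold lower number from compound 2 to compound 4 (0.15 log units; within the scatter).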

Compound 4, half-maximal inhibitory concentration: > 10000 nM
Compound 4: a limit, no number; the forecaster's own chance of this, stated with the estimate: 5%; middle value at least 8.3-fold (0.92 log units) away from the limit.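

Replacing 4-methoxy-3-(trifluoromethyl)phenyl with 4-acetamidophenyl on the amide-type nitrogen gives an at least 5.8-fold higher number from compound 2 to compound 4 (0.76 log units; beyond the scatter), the opposite direction to a 2.4-fold lower number from compound 2 to compound 3 (0.39 log units; beyond the scatter). This position therefore does not accept every change, which the earlier replacement of methoxy alone did not show. Compound 4 gives a limit, not a number: the limit of > 10000 nM in this assay, at which 2 of the 4 values shown sit.

From the compounds shown here alone, this change removes the methoxy and the trifluoromethyl together and brings in the acetamido group, so the share of each remains open. Also open, going by these compounds, is how an amine or a carboxylic acid in place of the acetamido group would read.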